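This account rests on a few compounds, and the source may have more. Where it says the series, first, only, none or still open, it means among the compounds named here.

Compound 1 `NC(=O)N1CCN(C(=S)SCc2cn(Cc3ccccc3F)nn2)CC1` is the reference. In a functional assay on MGC-803 cells (Homo sapiens) for cytotoxicity, read by MTT assay, with a stated time of 72 h (a higher number here means a weaker inhibitor, a lower number a stronger inhibitor), compound 1 gives 11300 nM. Compound 2 `CCNC(=O)N1CCN(C(=S)SCc2cn(Cc3ccccc3F)nn2)CC1` differs from it by ethyl in place of hydrogen on an amide-type nitrogen, and in this assay compound 2 gives 2830 nM, so that a 4.0-fold lower number from compound 1 to compound 2 (0.60 log units; beyond the scatter). Compound 3 `COc1ccc(Cn2cc(CSC(=S)N3CCN(C(N)=O)CC3)nn2)cc1` differs from compound 1 by 4-methoxyphenyl in place of 2-fluorophenyl on a saturated chain carbon bound to an aromatic nitrogen. In this assay compound 3 shows only a limit, > 128000 nM, which is the limit of > 128000 nM in this assay, at which 1 of the 3 values shown sits. The step of an at least 11-fold higher number from compound 1 to compound 3 (1.05 log units; beyond the scatter) is accordingly known only as a bound. Compound 4 `CCNC(=O)N1CCN(C(=S)SCc2cn(Cc3ccc(OC)cc3)nn2)CC1` has not yet been measured in this assay. It differs from compound 3 by ethyl in place of hydrogen on an amide-type nitrogen, the same change as was made from compound 1 to compound 2, at a place described in the same words. Because a 4.0-fold lower number from compound 1 to compound 2 (0.60 log units; beyond the scatter), the step from compound 3 to compound 4 is expected to be of similar size, an at least 2.5-fold lower number from compound 3 to compound 4 (0.40 log units; beyond the scatter), though it starts from a limit and the measured steps involve only these three compounds. Compound 4 is therefore expected to give about 50000 nM in this assay. The estimated range for compound 4 runs from 15000 nM to 160000 nM.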

Compound 4, half-maximal inhibitory concentration: > 128000 nM
Compound 4: only a limit was reported; the forecaster's own chance of this, stated with the estimate: 45%; at least 2.5-fold (0.40 log units) between middle value and limit.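

In this assay compound 4 gives > 128000 nM, which is a limit and not a number, and compound 3 also stands at a limit, so the step from ethyl in place of hydrogen cannot be read on the 4-methoxyphenyl core: the limit of > 128000 nM in this assay, at which 2 of the 4 values shown sit. Carrying 4-methoxyphenyl in place of 2-fluorophenyl onto the core that bears the ethyl group gives an at least 45-fold higher number from compound 2 to compound 4 (1.65 log units; beyond the scatter), so the number rises on this core too. The change thus runs in the same direction on both cores, but both sizes are only bounds, and the data do not show whether it is equally large on each: the same change on two cores in this assay, an at least 11-fold higher number (1.05 log units; beyond the scatter) from compound 1 to compound 3 and an at least 45-fold higher number (1.65 log units; beyond the scatter) from compound 2 to compound 4; the limit leaves it open whether they differ.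

The compounds shown leave open whether the lower number that ethyl gave with 2-fluorophenyl carries over to any core that reads below the limit. They also leave open how a longer chain such as propyl on the amide-type nitrogen, or a plain phenyl in place of 2-fluorophenyl, would read in this assay.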